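Cyclohexyl in place of methyl on a diacylhydrazine nitrogen

This account rests on a few compounds, and the source may have more. Where it says the series, first, only, none or still open, it means among the compounds named here.

Compound 1 `CC(C)(C)N(NC(=O)c1ccc(C#N)cc1)C(=O)c1ccccc1Cl` is tested in an assay on cells for agonist activity at ecdysone receptor (Bombyx mori), read by a luciferase reporter, with a stated time of 24 h (on this read-out higher numbers stand for an effect only at larger amounts of compound and lower numbers for an effect already at smaller amounts), and gives 603 nM. Compound 2 `CN(NC(=O)c1ccccc1)C(=O)c1ccccc1` shares the diacylhydrazine core but carries a methyl group on one amide-type nitrogen and plain unsubstituted phenyl rings on both carbonyls. In this assay compound 2 reaches only > 100000 nM, which is a limit of the assay and not a measured number. This is the limit of > 100000 nM in this assay, at which 1 of the 2 values shown sits, so compound 2 stands at the weak end of what the assay can report, while compound 1 sits well inside the measurable range.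

Compound 3 `O=C(NN(C(=O)c1ccccc1)C1CCCCC1)c1ccccc1` has not yet been measured. It differs from compound 2 in one place: cyclohexyl in place of methyl on an amide-type nitrogen. The two measured compounds show that a small methyl on this nitrogen gives no measurable effect, whereas the tert-butyl of compound 1 gives a clear one. A large step toward a lower number is therefore expected, written as an at least 5.0-fold lower number from compound 2 to compound 3 (0.69 log units; beyond the scatter). In this assay compound 3 is expected to give about 20000 nM, within a range from 2000 nM to 150000 nM.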

Compound 3, half-maximal effective concentration: 891 nM
Compound 3: the middle estimate sits 22-fold (1.35 log units) above what was measured, and the stated range ends above it.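

In this assay, replacing methyl with cyclohexyl on the amide-type nitrogen gives an at least 110-fold lower number from compound 2 to compound 3 (2.05 log units; beyond the scatter). Compound 1 and compound 2 differ in more than one place, so they could not show what this nitrogen group contributes by itself; compound 2 and compound 3 share the same plain phenyl rings and differ only in this group, which shows that this one change is enough to turn a compound with no measurable effect into one with a measured value, even without the chloro and nitrile groups of compound 1. The true size of the step remains unknown, since the value for compound 2 is a limit of the assay and not a number: the limit of > 100000 nM in this assay, at which 1 of the 3 values shown sits.

The compounds shown leave open whether cyclohexyl is specifically needed here, or whether a cyclopentyl group, a phenyl ring or a straight hexyl chain on this nitrogen would give a similar result. They also leave open how a tert-butyl group would compare with cyclohexyl on the plain phenyl rings, and whether adding a chloro or nitrile group to the rings of compound 3 would change its value.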